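This account rests on a few compounds, and the source may have more. Where it says the series, first, only, none or still open, it means among the compounds named here.

In an assay on isolated protein for inhibition of serine protease 1 (Bos taurus) (on this read-out lower numbers stand for stronger inhibition and higher numbers for weaker inhibition), compound 2 `Cc1c(F)c(Oc2cccc(N)c2)nc(Oc2cccc(C(=N)N)c2)c1F` gives > 5000 nM, which is a limit of the assay and not a number. Compound 1 `Cc1c(F)c(Oc2cccc(C(=N)N)c2)nc(Oc2cccc([N+](=O)[O-])c2)c1F` in this assay likewise gives > 5000 nM, again a limit. Compound 3 `Cc1c(F)c(Oc2cccc(OC(C)C)c2)nc(Oc2cccc(C(=N)N)c2)c1F` in this assay gives 2900 nM. Compound 2 therefore stands at the limit, shared by compound 1 (the limit of > 5000 nM in this assay, at which 2 of the 3 values shown sit), while compound 3 alone carries a number.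

Compound 4 `Cc1c(F)c(Oc2cccc(C(=N)N)c2)nc(Oc2cccc([S+]([O-])N(C)C)c2)c1F` differs from compound 2 in one place: a group of 5 heavy atoms (2 carbon, 1 nitrogen, 1 oxygen, 1 sulfur; no ring) in place of one nitrogen atom, on an aromatic carbon. The nearest measured step exchanges the same amino group: an at least 1.7-fold lower number from compound 2 to compound 3 (0.23 log units; that floor lies within the scatter). A step of the same kind, an at least 1.7-fold lower number from compound 1 to compound 3 (0.23 log units; that floor lies within the scatter), points the same way, and a third step, a step that the two limits leave unreadable from compound 1 to compound 2, cannot be read. Among the measured compounds shown here, no measured step exchanges the amino group for a group of 5 heavy atoms of this make-up, so the expectation rests on weak inhibition throughout. For compound 4 the expected value is therefore near the limit, estimated at 4000 nM with a range from 1000 nM to 15000 nM. That estimate means an expected step of an at least 1.2-fold lower number from compound 2 to compound 4 (0.09 log units; that floor lies within the scatter), within the scatter.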

Compound 4, inhibition constant: 2400 nM
Compound 4: the middle estimate sits 1.7-fold (0.22 log units) above what was measured, and the stated range covers the measured number.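

In this assay, among the compounds shown here, the group of 5 heavy atoms at this aromatic carbon gives the first steps that are readable beyond the scatter: an at least 2.0-fold lower number from compound 2 to compound 4 (0.31 log units; beyond the scatter) and an at least 2.0-fold lower number from compound 1 to compound 4 (0.31 log units; beyond the scatter). Against the isopropoxy group the same exchange shows no difference that can be told, with a 1.2-fold lower number from compound 3 to compound 4 (0.08 log units; within the scatter), so two groups of quite different make-up both give a number here, while amino and nitro do not. Compound 1 and compound 2 each carry a limit and not a number, so the two larger steps are only floors: the limit of > 5000 nM in this assay, at which 2 of the 4 values shown sit.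

The compounds shown cannot tell which part of the entering group matters for inhibition. As far as these compounds go, whether a dimethylamino group, a carboxylic acid or a longer alkoxy chain at this place would lower the number further also stays open.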